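Phenyl for Vinyl: What to Expect of Compound 4

The source may report more compounds than this note shows. Statements on the series, on what has been measured and on what is new or still open speak of the compounds shown alone.

Measured compounds:
Compound 1, `C=CCOCc1cc(-c2cc(CC=C)ccc2OC)no1`: in a functional assay on BV-2 cells (Mus musculus) for inhibition, read by Griess assay, with a stated time of 24 h (a higher number here means a weaker inhibitor, a lower number a stronger inhibitor), compound 1 gives 28700 nM.
Compound 2, `C=CCc1ccc(OC)c(-c2cc(COCc3ccccc3)on2)c1`: for compound 2 the assay reports only a limit, > 200000 nM.
Compound 3, `C=CCn1ccc(-c2cc(Br)ccc2O)n1`: in this assay compound 3 gives 112000 nM.

Compound 1 and compound 2 share one core and differ in a single place: phenyl in place of vinyl on a saturated chain carbon bound to an oxygen on a saturated carbon. That change gives an at least 6.9-fold higher number from compound 1 to compound 2 (0.84 log units; beyond the scatter). The true size of the step is known only as a lower bound because of the limit of > 200000 nM in this assay, at which 1 of the 3 values shown sits.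

Compound 4, `Oc1ccc(Br)cc1-c1ccn(Cc2ccccc2)n1`, has not yet been measured. It is built on the core of compound 3; the difference between that core and the core of compound 1 is not broken down here. Compound 4 differs from compound 3 by phenyl in place of vinyl on a saturated chain carbon bound to an aromatic nitrogen. Among the compounds with values here, this is the same kind of change as the one from compound 1 to compound 2, but not the same change: in the measured pair the place was on a saturated chain carbon bound to an oxygen on a saturated carbon, whereas here it is on a saturated chain carbon bound to an aromatic nitrogen.

Of the two numbers measured, compound 3 stands higher, with compound 1 giving a lower number by a gap beyond the scatter. The expectation for compound 4 rests on an at least 6.9-fold higher number from compound 1 to compound 2 (0.84 log units; beyond the scatter) and on the change being of the same kind. The expected step is a 3.1-fold higher number from compound 3 to compound 4 (0.49 log units; beyond the scatter). Compound 4 is thus estimated at 350000 nM, between 90000 nM and 1200000 nM. Since that range sits near the limit, the assay may well report only a limit for compound 4.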

Compound 4, half-maximal inhibitory concentration: > 200000 nM
Compound 4 was reported as a limit (the forecaster's own chance of this, stated with the estimate: 60%); the middle value lies beyond the limit too.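

In this assay compound 4 gives only a limit, > 200000 nM. Phenyl in place of vinyl on a saturated chain carbon bound to an aromatic nitrogen therefore gives an at least 1.7-fold higher number from compound 3 to compound 4 (0.25 log units; that floor lies within the scatter), so this result does not go against the weaker inhibition seen on the first core, but on its own it does not establish a real loss on the second core. Set beside the earlier step, it shows that the change can be carried to the second core without any sign of a stronger inhibitor, yet it does not show whether the change has the same size on both cores: the same change on two cores in this assay, an at least 6.9-fold higher number (0.84 log units; beyond the scatter) from compound 1 to compound 2 and an at least 1.7-fold higher number (0.25 log units; that floor lies within the scatter) from compound 3 to compound 4; the limit leaves it open whether they differ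

The compounds shown leave open what other groups would do in this place, for example an ethyl group, a longer chain or a chain ending in an amine. They also leave open how weak compound 2 and compound 4 really are, and so how large the step is on either core: the limit of > 200000 nM in this assay, at which 2 of the 4 values shown sit.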